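Biaryl substituent swap from compound 3 to compound 4

This account rests on a few compounds, and the source may have more. Where it says the series, first, only, none or still open, it means among the compounds named here.

Compound 3 `COC(=O)/C=C/c1cccc(N(Cc2ccc(-c3ccc(F)c(F)c3)cc2)C(=O)C2CCCCC2)c1` gives 72 nM in an assay on isolated protein with Bile acid receptor (Homo sapiens) as the target; on this read-out lower numbers stand for an effect already at smaller amounts and higher numbers for an effect only at larger amounts of compound; this is the second highest of three numbers, nearest to compound 1 `COC(=O)/C=C/c1cccc(N(Cc2ccc(/C=C/c3ccccc3F)cc2)C(=O)C2CCCCC2)c1` with 64 nM and furthest from compound 2 `COC(=O)/C=C/c1cccc(N(Cc2ccc(/C=C/c3ccccn3)cc2)C(=O)C2CCCCC2)c1` with 309 nM. Going by the values given here, the two steps into compound 3, a 1.1-fold higher number from compound 1 to compound 3 (0.05 log units; within the scatter) and a 4.3-fold lower number from compound 2 to compound 3 (0.63 log units; beyond the scatter), both exchange an ethenyl-linked aryl for 3,4-difluorophenyl; no measured step changes the substituent of a 3,4-difluorophenyl or similar ring itself. Compound 4 `COC(=O)/C=C/c1cccc(N(Cc2ccc(-c3cccc(C)c3)cc2)C(=O)C2CCCCC2)c1` differs from compound 3 by 3-methylphenyl in place of 3,4-difluorophenyl on an aromatic carbon. Without a step of this kind on record, the expected change is small, a 1.3-fold higher number from compound 3 to compound 4 (0.10 log units; within the scatter), with no firm direction. Compound 4 is therefore estimated at 90 nM in this assay, with a range from 35 nM to 250 nM.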

Compound 4, half-maximal effective concentration: 109 nM
Estimate against measurement, compound 4: 1.2-fold (0.08 log units) below, and the stated range covers the measured number.
By their numbers in this assay, from the lowest: compounds 1, 3 and 4 (each within the scatter of the next); then compound 2.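

In this assay, going by these compounds alone, a 1.5-fold higher number from compound 3 to compound 4 (0.18 log units; within the scatter) is the first reading of a change on this ring itself: 3-methylphenyl in place of 3,4-difluorophenyl, para to a large group, stays within the scatter. Against the ethenyl-linked aryls, 3-methylphenyl repeats the pattern of 3,4-difluorophenyl, with a 1.7-fold higher number from compound 1 to compound 4 (0.23 log units; within the scatter) and with a 2.8-fold lower number from compound 2 to compound 4 (0.45 log units; beyond the scatter). No measurement offered here accounts for these steps. From the compounds shown here alone, what an amine or a carboxylic acid in place of the methyl would do to the number stays open.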